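Trading a Phenyl for an Ethyl at the Branch Point

A few compounds are considered here, and "the series" means these few. Any claim that something is new, unique, unknown or untested is made for them only; others in the source may bear on it.

Three agonists sharing one core have been tested in a functional assay on Right cardiac atrium for agonist activity at histamine H2 receptor (Cavia porcellus), with a stated time of 30 min, in the presence of a further agent that is not named here; on this read-out lower numbers stand for smaller maximal responses and higher numbers for larger maximal responses. Compound 1 `Cc1nc(N)sc1CCCN/C(N)=N/C(=O)NC(c1ccccc1)C(C)C` gives 1.04. Compound 2 `Cc1nc(N)sc1CCCN/C(N)=N/C(=O)NC(c1ccccc1)c1ccccc1` gives 0.9. Compound 3 `Cc1ccc(C(C)NC(=O)/N=C(\N)NCCCc2sc(N)nc2C)cc1` gives 0.85.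

Among these three numbers compound 2 stands second highest. Its nearest neighbour is compound 3, which sits lower by an amount within the scatter, so the two cannot be told apart. Compound 1 lies furthest away, higher by an amount beyond the scatter.

Within the data shown here, one measured step bears on the question ahead. Going a number 0.14 lower from compound 1 to compound 2 (beyond the scatter), the maximal response fell modestly once a phenyl replaced an isopropyl on the same chain carbon.

The unmeasured compound 4 `CCC(NC(=O)/N=C(\N)NCCCc1sc(N)nc1C)c1ccccc1` differs from compound 2 in that same place: ethyl in place of phenyl on a saturated chain carbon bound to an amide-type nitrogen and an aromatic carbon. Since a small alkyl group now returns where the phenyl had been, the step from compound 1 to compound 2 suggests the change may be partly undone, and a modest rise in this assay is expected, expressed as a number 0.10 higher from compound 2 to compound 4 (within the scatter). Compound 4 is therefore estimated to give 1, with a likely range from 0.85 to 1.15.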

Compound 4, intrinsic activity: the largest response reached, as a fraction of the reference agonist's: 0.93
Compound 4: the middle estimate sits 0.070 above what was measured; measured number inside the range.
By their numbers in this assay, from the lowest: compounds 3, 2 and 4 (each within the scatter of the next); then compound 1.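

In this assay, the step from a phenyl to an ethyl on this carbon gives a number 0.030 higher from compound 2 to compound 4 (within the scatter) and so shows no difference that can be told apart, even though a ring of 6 carbon atoms gives way to a chain of 2 with no ring. Removing one methyl from the isopropyl of compound 1 leaves the ethyl of compound 4 and gives a number 0.11 lower from compound 1 to compound 4 (beyond the scatter) as a modest step beyond the scatter, so among compounds 1, 2 and 4 it is the isopropyl compound that stands apart, while the ethyl and phenyl compounds do not separate. At this position, then, the line does not fall simply between alkyl and aromatic groups, and no measurement at hand explains why losing one methyl registers when exchanging a whole phenyl for an ethyl does not.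

Among these compounds, with isopropyl as the only branched alkyl group here, it remains open whether the higher maximal response belongs to branching in general or to this one group. A tert-butyl group, a cyclopropyl ring or a longer straight chain such as propyl on the same carbon would help to decide this.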